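This account rests on a few compounds, and the source may have more. Where it says the series, first, only, none or still open, it means among the compounds named here.

Measured compounds:
compound 1 `ClCc1ccccc1Cn1cnc2c(Cl)nc(Cl)nc21`, 1540 nM
compound 2 `ClCc1cccc(Cn2cnc3c(Cl)ncnc32)c1`, 16200 nM
compound 3 `ClCc1ccc(Cn2cnc3nc(Cl)nc(Cl)c32)cc1`, 28200 nM

The read-out throughout is a functional assay on RPMI-8226 cells (Homo sapiens) for cytotoxicity, read by sulforhodamine B assay, with a stated time of 48 h; on this read-out lower numbers stand for stronger inhibition of growth and higher numbers for weaker inhibition of growth. On this read-out compound 3 gives the highest of the three numbers. Its nearest neighbour is compound 2, which in this assay gives 16200 nM, a gap that lies within the scatter, so no order between compound 2 and compound 3 can be claimed. The gap to compound 1, which gives 1540 nM, lies beyond the scatter.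

Compound 4 `ClCc1ccc(Cn2cnc3ncnc(Cl)c32)cc1` is not yet measured. It differs from compound 3 by hydrogen in place of chloro on an aromatic carbon between two ring nitrogen atoms. Going by the values given here, no pair of measured compounds differs in this one place, so the size of this step is unknown; compound 2 carries a single chloro on the core and compound 3 two, but they also differ in the benzyl substitution pattern, so their numbers show only that both lie within the scatter of each other.

For compound 4 the step of a 1.2-fold higher number from compound 3 to compound 4 (0.09 log units; within the scatter) is expected to stay within the scatter, with a small lean to a higher number. The estimate for compound 4 is 35000 nM, in the range 12000 nM to 100000 nM.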

Compound 4, concentration for total growth inhibition: 2690 nM
Compound 4: the middle estimate sits 13-fold (1.11 log units) above what was measured, outside the stated range (below it).
By their numbers in this assay, from the lowest: compounds 1 and 4 (each within the scatter of the next); then compounds 2 and 3 (each within the scatter of the next).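

In this assay, going by these compounds alone, hydrogen in place of chloro on an aromatic carbon between two ring nitrogen atoms is a large step (a 10-fold lower number from compound 3 to compound 4 (1.02 log units; beyond the scatter)), and it is the first comparison that changes one place only. This position therefore has a strong bearing on the read-out, and for this pair, losing the chloro goes with stronger inhibition of growth. No measurement shown here explains the size of this step.

The compounds shown leave open whether the same change gives a step of similar size with the chloromethyl group placed as in compound 1 or compound 2, since this pair is the only reading of it. They also leave open how an amine, a methoxy group or a nitrile on this carbon would compare with hydrogen and chloro.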